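A few compounds are considered here, and "the series" means these few. Any claim that something is new, unique, unknown or untested is made for them only; others in the source may bear on it.

Of the compounds shown here, three with a shared core have been measured in a functional assay on PANC-1 cells (Homo sapiens) for inhibition, read by MTT assay, with a stated time of 24 h, tested at 10 uM; a lower number here means less inhibition, a higher number more inhibition at the concentration tested (going by the name of the read-out). Compound 1 `CC(C)=CCC/C(C)=C/COc1cc(=O)n(CCCO)c2c1CC(CC=C(C)C)C(C)(C)C2` gives 10.6%. Compound 2 `CC(C)=CCC1Cc2c(OCCCOc3ccc([N+](=O)[O-])cc3)cc(=O)n(CCCO)c2CC1(C)C` gives 47.5%. For the measured compounds named here, compound 3 `CC(C)=CCC/C(C)=C/COc1cc(=O)n(CCCO)c2c1CC(C/C=C(\C)CCC=C(C)C)C(C)(C)C2` gives 15.8%, which places compound 3 second highest of the three numbers, nearest to compound 1 within the scatter and far from compound 2 beyond it; the step of a number 5.2 percentage points higher from compound 1 to compound 3 (within the scatter) is the only difference between compound 1 and compound 3.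

Compound 4 `COc1ccc(OCCCOc2cc(=O)n(CCCO)c3c2CC(C/C=C(\C)CCC=C(C)C)C(C)(C)C3)cc1` has not yet been measured. Against compound 3 its change is 2-(4-methoxyphenoxy)ethyl in place of 2,6-dimethylhepta-1,5-dien-1-yl on a saturated chain carbon bound to an oxygen on an aromatic ring. The measured step that bears on this is a number 36.9 percentage points higher from compound 1 to compound 2 (beyond the scatter), where a 2-(4-nitrophenoxy)ethyl group entered at the same place on a saturated chain carbon bound to an oxygen on an aromatic ring. Compound 4 carries a 2-(4-methoxyphenoxy)ethyl group instead, so the same direction is expected, possibly with a somewhat smaller size, as no nitro-to-methoxy comparison exists here. Compound 4 is therefore estimated at 40%, between 20% and 60%, a step of a number 24.2 percentage points higher from compound 3 to compound 4 (beyond the scatter).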

Compound 4, a percentage reported as inhibition, at one concentration (the size of the read-out at that concentration, not a potency): 20%
Compound 4: middle estimate off by 20 percentage points, on the high side; the measured number falls inside the stated range.
By their numbers in this assay, from the lowest: compounds 1, 3 and 4 (each within the scatter of the next); then compound 2.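

At the place on a saturated chain carbon bound to an oxygen on an aromatic ring, exchanging 2,6-dimethylhepta-1,5-dien-1-yl for an aryl ether chain does not always bring a large change in this assay: 2-(4-methoxyphenoxy)ethyl gives a number 4.2 percentage points higher from compound 3 to compound 4 (within the scatter). The large step seen earlier, a number 36.9 percentage points higher from compound 1 to compound 2 (beyond the scatter), therefore does not hold for every phenoxyethyl group or on every background, as it did not carry over to this methoxy-bearing group on the compound 3 background. No measurement shown here explains this difference between the two steps.

Compound 2 and compound 4 differ both in the nitro or methoxy group and in the other chain on the core, so the compounds shown cannot say which of the two goes with the larger step. On these data alone, how an unsubstituted phenoxy ring or an amine at the end of this chain would read also remains open.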